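Chloro on the fused ring of compound 3: an expected cost

This account rests on a few compounds, and the source may have more. Where it says the series, first, only, none or still open, it means among the compounds named here.

Measured compounds:
- compound 1, `O=C(Nc1nc2ccccc2s1)c1cn(-c2ccccc2)nc1-c1ccccc1`, 13500 nM
- compound 2, `COc1ccc2nc(NC(=O)c3cn(-c4ccccc4)nc3-c3ccccc3)sc2c1`, > 50000 nM (a limit)
- compound 3, `O=C(Nc1nc2ccccc2s1)c1cn(-c2ccccc2)nc1-c1ccc(F)cc1`, 9010 nM

In a functional assay on A549 cells (Homo sapiens) for cytotoxicity, read by MTT assay, with a stated time of 72 h (on this read-out higher numbers stand for weaker inhibition and lower numbers for stronger inhibition), compound 1 gives 13500 nM. Compound 2 reaches only the limit of this assay, > 50000 nM. Compound 3 gives 9010 nM in this assay, the lowest of the two numbers shown, and its step from compound 1 is a 1.5-fold lower number from compound 1 to compound 3 (0.18 log units; within the scatter), within the scatter. The unmeasured compound 4, `O=C(Nc1nc2ccc(Cl)cc2s1)c1cn(-c2ccccc2)nc1-c1ccc(F)cc1`, differs from compound 3 by chloro in place of hydrogen on an aromatic carbon, a change on an aromatic carbon of a six-membered aromatic ring of carbon only, part of a fused or bridged system of two rings. For the measured compounds named here, the one step that bears on a substituent on this fused ring is an at least 3.7-fold higher number from compound 1 to compound 2 (0.56 log units; beyond the scatter), where a methoxy there reached (the limit of > 50000 nM in this assay, at which 1 of the 3 values shown sits). Chloro is not methoxy, and no chloro step is available, so a weakening of modest size is expected, possibly none beyond the scatter. Compound 4 is therefore estimated at 16000 nM, between 5000 nM and 50000 nM, an expected step of a 1.8-fold higher number from compound 3 to compound 4 (0.25 log units; within the scatter).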

Compound 4, half-maximal inhibitory concentration: 3870 nM
For compound 4 the middle estimate is 4.1-fold (0.62 log units) above the measured one; measured number outside the range, below it.
By their numbers in this assay, from the lowest: compound 4; then compounds 3 and 1 (each within the scatter of the next). At a limit, above all of these: compound 2.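

In this assay, 6-chloro-1,3-benzothiazol-2-yl in place of 1,3-benzothiazol-2-yl gives a 2.3-fold lower number from compound 3 to compound 4 (0.37 log units; beyond the scatter), the only step shown that is beyond the scatter and moves toward stronger inhibition. For the compounds shown here, until now the one substituent step on the fused ring pointed the other way, an at least 3.7-fold higher number from compound 1 to compound 2 (0.56 log units; beyond the scatter), so a substituent on this ring does not carry a single direction of effect; the two steps also start from different compounds, and they differ in the group that enters. Compound 2 stands at a limit, not at a number: the limit of > 50000 nM in this assay, at which 1 of the 4 values shown sits.

From the compounds shown here alone, whether chloro would give a similar step on the unfluorinated compound 1 stays open. So does what a methyl group, a bromo group or an amine would do at this same place on the fused ring.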